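The compounds below may be only part of what the source reports. "The series", "measured", "known", "first", "only" and "open" are said of these compounds alone.

In a functional assay for activation of Alpha-1A adrenergic receptor (Homo sapiens), read by calcium flux (on this read-out higher numbers stand for an effect only at larger amounts of compound and lower numbers for an effect already at smaller amounts), compound 2 `c1csc(-c2ccccc2OCC2=NCCN2)c1` gives 1 nM and compound 3 `c1c[nH]c(-c2ccccc2OCC2=NCCN2)c1` gives 1.26 nM. Compound 1 `c1ccc(-c2ccncc2)c(OCC2=NCCN2)c1` yields only a limit, < 100000 nM. Compound 3 thus holds the higher of the two readable numbers, yet a 1.3-fold higher number from compound 2 to compound 3 (0.10 log units; within the scatter) stays within the scatter. The steps from compound 1 to compound 2 and from compound 1 to compound 3 cannot be sized because of the limit of < 100000 nM in this assay, at which 1 of the 3 values shown sits.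

Compound 4 `c1ccc(-c2ccoc2)c(OCC2=NCCN2)c1` differs from compound 3 by furan-3-yl in place of 1H-pyrrol-2-yl on an aromatic carbon. Going by the values given here, the one readable step that bears on this exchange is a 1.3-fold higher number from compound 2 to compound 3 (0.10 log units; within the scatter), where one five-membered aromatic ring with one hetero atom replaced another without leaving the scatter; furan-3-yl is again such a ring. For compound 4 in this assay the expected value is 3 nM, with a range from 0.8 nM to 15 nM. This amounts to an expected 2.4-fold higher number from compound 3 to compound 4 (0.38 log units; beyond the scatter).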

Compound 4, half-maximal effective concentration: 0.501 nM
For compound 4 the middle estimate is 6.0-fold (0.78 log units) above the measured one, and the stated range ends above it.
By their numbers in this assay, from the lowest: compounds 4, 2 and 3 (each within the scatter of the next, the first and the last beyond it).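

In this assay, going by these compounds alone, furan-3-yl in place of 1H-pyrrol-2-yl gives a 2.5-fold lower number from compound 3 to compound 4 (0.40 log units; beyond the scatter) and is the only exchange between five-membered aromatic rings at this position to leave the scatter, though modestly. Against thiophen-2-yl the same ring gives a 2.0-fold lower number from compound 2 to compound 4 (0.30 log units; within the scatter) and stays within the scatter, so only compound 3 and compound 4 separate. The step from compound 1 to compound 4 cannot be read, as the value of compound 1 is a limit: the limit of < 100000 nM in this assay, at which 1 of the 4 values shown sits.

Going by these compounds, whether the step from compound 3 follows the hydrogen-bond donor that leaves, the acceptor that enters or the change of ring stays open. On these data alone, how a plain phenyl or a furan-2-yl group would read at this place is also open.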